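Sulfonamide proline anilides: paw edema at one dose

The source may hold more compounds than are shown below. What is called first, only, known or untested is meant among the compounds shown, and "the series" means these compounds.

Measured compounds in a functional assay on the whole organism for inhibition, with Rattus norvegicus as the target, read by paw edema, with stated times of 1 h and 2 h, at a dose of 100 mg/kg by the oral route; on this read-out lower numbers stand for less inhibition and higher numbers for more inhibition at the one dose given (going by the name of the read-out):
- compound 1, `Cc1ccc(S(=O)(=O)N2CC(O)C[C@H]2C(=O)Nc2ccc(C(=O)O)cc2)cc1`, 67.2%
- compound 2, `Cc1ccccc1S(=O)(=O)N1CCC[C@H]1C(=O)Nc1ccc(C(=O)O)cc1`, 36.3%
- compound 3, `O=C(O)c1ccc(NC(=O)[C@@H]2CCCN2S(=O)(=O)c2ccccc2)cc1`, 29.4%

Compound 2 stands second highest of the three numbers in this assay. Its nearest neighbour is compound 3, reached by a number 6.9 percentage points lower from compound 2 to compound 3 (within the scatter), a step within the scatter, so no order between the two is claimed. Among the compounds with values here, compound 1 lies furthest from compound 2, with a number higher than that of compound 2 by an amount beyond the scatter; compound 1 differs from compound 2 in more than one place, so no single step is drawn between them.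

Compound 4, `O=C(O)c1ccc(NC(=O)[C@@H]2CCCN2S(=O)(=O)c2ccc([N+](=O)[O-])cc2)cc1`, is not yet measured in this assay. It differs from compound 2 as follows: 4-nitrophenyl in place of 2-methylphenyl on a sulfonyl sulfur.

Within the data shown here, the only measured step at the same place is the one from compound 2 to compound 3, where hydrogen replaced methyl on an aromatic carbon with a change within the scatter. Among the measured compounds shown here, no measured compound carries a nitro group, so the size of the present step is not anchored by data. For the measured compounds named here, on the single step at this position, compound 4 is expected to stay close to compound 2, with a step of a number 3.3 percentage points lower from compound 2 to compound 4 (within the scatter), that is, none beyond the scatter. The estimate for compound 4 in this assay is 33%, with a range from 15% to 55%.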

Compound 4, a percentage reported as inhibition, in the whole organism at one dose (the size of the read-out at that dose, not a potency): 50.1%
Compound 4: the middle estimate sits 17.1 percentage points below what was measured; low and high end bracket the measured number.
By their numbers in this assay, from the lowest: compounds 3 and 2 (each within the scatter of the next); then compound 4; then compound 1.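

In this assay, the aryl group on the sulfonyl sulfur no longer looks indifferent: nitro in place of hydrogen on an aromatic carbon gives a number 20.7 percentage points higher from compound 3 to compound 4 (beyond the scatter), and 4-nitrophenyl in place of 2-methylphenyl gives a number 13.8 percentage points higher from compound 2 to compound 4 (beyond the scatter). Within the data shown here, the earlier change at this aryl group, a number 6.9 percentage points lower from compound 2 to compound 3 (within the scatter), did not separate compound 2 from compound 3, so the first change here beyond the scatter comes with the nitro group, which adds two hydrogen-bond acceptors by the count of the group, though the steps rest on this single nitro compound and a single dose. No measurement at hand explains why the number moves with this change.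

As far as these compounds go, it remains open whether the rise belongs to nitro itself, since an amine, a methoxy group or a carboxylic acid on the same aromatic carbon would be needed to tell whether other groups there give a like step. Also open, from the compounds shown here alone, is whether 4-nitrophenyl on the sulfonyl sulfur of the hydroxyl-bearing core of compound 1, which stands at 67.2%, would change that number.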